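Chain extension in the alkoxy series: the next step

The compounds below may be only part of what the source reports. "The series", "measured", "known", "first", "only" and "open" are said of these compounds alone.

Compound 1 `CCCCCCCCCCOC1=C(O)OC(C(O)CO)C1=O` is the shortest-chain member recorded. Within the data shown here, in a functional assay (brain) for inhibition, with Rattus norvegicus as the target (on this read-out lower numbers stand for stronger inhibition and higher numbers for weaker inhibition), compound 1 gives 13000 nM, which is the highest of the three numbers so far. Compound 2 `CCCCCCCCCCCCCOC1=C(O)OC(C(O)CO)C1=O` gives 7400 nM and compound 3 `CCCCCCCCCCCCCCCCOC1=C(O)OC(C(O)CO)C1=O` gives 6800 nM. The steps of a 1.8-fold lower number from compound 1 to compound 2 (0.24 log units; within the scatter) and a 1.9-fold lower number from compound 1 to compound 3 (0.28 log units; within the scatter) both lie inside the scatter, and a 1.1-fold lower number from compound 2 to compound 3 (0.04 log units; within the scatter) is smaller still, so the three measured compounds cannot be ranked with any confidence.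

Compound 4 `CCCCCCCCCCCCCCCCCCCCCOC1=C(O)OC(C(O)CO)C1=O` has not been measured. It differs from compound 1 by undecyl in place of hydrogen on a saturated chain carbon, ten or more bonds along the chain from an oxygen on an unsaturated carbon. Among the measured compounds shown here, the two measured steps of the same kind from compound 1, a 1.8-fold lower number from compound 1 to compound 2 (0.24 log units; within the scatter) and a 1.9-fold lower number from compound 1 to compound 3 (0.28 log units; within the scatter), are the only direct guides; both are within the scatter, and the further extension seen in a 1.1-fold lower number from compound 2 to compound 3 (0.04 log units; within the scatter) adds nothing that the scatter would not cover. For the measured compounds named here, no measured step reaches a chain as long as that of compound 4, so the expectation for this assay is a small step downward at most, or none beyond the scatter.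

Compound 4 is estimated at 6500 nM, with a range from 2500 nM to 16000 nM. The step expected from this estimate is a 2.0-fold lower number from compound 1 to compound 4 (0.30 log units; within the scatter).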

Compound 4, half-maximal inhibitory concentration: 11000 nM
Beside the measured number, compound 4's estimate is 1.7-fold (0.23 log units) below it; the range from low to high includes it.
By their numbers in this assay, from the lowest: compounds 3, 2, 4 and 1 (each within the scatter of the next).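

Undecyl in place of hydrogen at this chain position gives a 1.2-fold lower number from compound 1 to compound 4 (0.07 log units; within the scatter), so even this large addition to the chain of compound 1 produces no step that can be told from the scatter in this assay. The earlier steps shown here all printed as lower numbers, whereas the two new steps from the intermediate chains print as higher numbers, a 1.6-fold higher number from compound 3 to compound 4 (0.21 log units; within the scatter) and a 1.5-fold higher number from compound 2 to compound 4 (0.17 log units; within the scatter); these also lie within the scatter, so they establish no reversal, and all four chain lengths remain unresolved in this read-out. No measurement bearing on why the numbers sit as they do is at hand.

The compounds shown leave open whether any change to this chain can move the number beyond the scatter, since every step among them stays inside it. As far as these compounds go, a much shorter chain such as butyl, or a chain carrying a carboxylic acid or an amine, would test whether the read-out responds at this position at all, and the core itself stays unexplored here.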